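Removing the aromatic hydroxy: compound 2 to compound 3

The source may hold more compounds than are shown below. What is called first, only, known or untested is meant among the compounds shown, and "the series" means these compounds.

Measured compounds:
Compound 1 `COc1ccc(NC(=O)c2nc(-c3cc(OC)c(OC)c(OC)c3)n(-c3ccc(OC)cc3)n2)cc1`, 51%
Compound 2 `COc1ccc(-n2nc(C(=O)Nc3ccc(O)cc3)nc2-c2cc(OC)c(OC)c(OC)c2)cc1`, 27%

In a functional assay on the whole organism for inhibition, with Rattus norvegicus as the target, read by paw edema, with stated times of 30 min and 5 h, at a dose of 0.28 mmol/kg by the oral route (on this read-out lower numbers stand for less inhibition and higher numbers for more inhibition at the one dose given (going by the name of the read-out)), compound 2 stands lowest of the two, with compound 1 nearest and the step of a number 24 percentage points lower from compound 1 to compound 2 (beyond the scatter) lying beyond the scatter. Compound 3 `COc1ccc(-n2nc(C(=O)Nc3ccccc3)nc2-c2cc(OC)c(OC)c(OC)c2)cc1` is not yet measured. It differs from compound 2 as hydrogen in place of hydroxy on an aromatic carbon. No measured step removes an oxygen from this ring; the only step shown, methyl to hydrogen on that oxygen, moved the read-out downward. With nothing directly comparable, compound 3 is expected to change by a number 6 percentage points higher from compound 2 to compound 3 (within the scatter), a step not beyond the scatter. Compound 3 is therefore estimated at 33%, between 12% and 55%.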

Compound 3, a percentage reported as inhibition, in the whole organism at one dose (the size of the read-out at that dose, not a potency): 46%
The estimate for compound 3 lay 13 percentage points below the measured number; low and high end bracket the measured number.
By their numbers in this assay, from the lowest: compound 2; then compounds 3 and 1 (each within the scatter of the next).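

In this assay, the low number of compound 2 goes with the hydroxy itself: replacing it with hydrogen gives a number 19 percentage points higher from compound 2 to compound 3 (beyond the scatter). Hydrogen in place of methoxy on the same aromatic carbon gives a number 5 percentage points lower from compound 1 to compound 3 (within the scatter), so the methoxy and the unsubstituted phenyl read alike here, and only the hydroxy stands apart. No evidence at hand says why this is so. As far as these compounds go, it remains open whether an amine or a carboxylic acid on this carbon would read with the hydroxy or with the other two.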